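Fluoro for methoxy on the pendant phenyl of compound 3

The source may hold more compounds than are shown below. What is called first, only, known or untested is meant among the compounds shown, and "the series" means these compounds.

Three compounds of the series carry numbers or reports in a functional assay on Hep 3B2 cells (Homo sapiens) for inhibition, read by sulforhodamine B assay, with a stated time of 72 h; a lower number here means a stronger inhibitor, a higher number a weaker inhibitor. Compound 1 `CC(C)Cc1ccc(C(C)c2n[nH]c(=S)n2N)cc1` gives 13100 nM. Compound 2 `CC(c1ccc(-c2ccccc2)c(F)c1)c1n[nH]c(=S)n1N` is reported as "not active" (no number reported), without a number. Compound 3 `COc1ccc(C2=Nn3c(nnc3C(C)c3ccc(-c4ccccc4)c(F)c3)SC2)cc1` gives 3500 nM, the lowest of the two numbers; compound 1 lies higher, and that gap is beyond the usual scatter.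

Compound 4 `CC(c1ccc(-c2ccccc2)c(F)c1)c1nnc2n1N=C(c1ccc(F)cc1)CS2` is not yet measured. It differs from compound 3 in one place: fluoro in place of methoxy on an aromatic carbon. Among the measured compounds shown here, no step between two measured compounds shows the same change, so nothing measured here sets its size. The change is small in what it counts, and the expectation is a step of no more than the scatter, with no clear direction.

On that basis compound 4 is expected to give about 4500 nM in this assay, with a range from 1500 nM to 14000 nM, which means an estimated step of a 1.3-fold higher number from compound 3 to compound 4 (0.11 log units; within the scatter).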

Compound 4, half-maximal inhibitory concentration: 2600 nM
The estimate for compound 4 lay 1.7-fold (0.24 log units) above the measured number; low and high end bracket the measured number.
By their numbers in this assay, from the lowest: compounds 4 and 3 (each within the scatter of the next); then compound 1.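

In this assay, among the compounds shown here, going from 4-methoxyphenyl to 4-fluorophenyl gives a 1.3-fold lower number from compound 3 to compound 4 (0.13 log units; within the scatter) and is the only measured step at this place. On this evidence, the aromatic carbon para to a large group carries either methoxy or fluoro with no difference that can be told from the scatter, something compound 1 and compound 2, which lack this pendant phenyl, could not show. Nothing on hand accounts for the two groups reading alike.

For the compounds shown here, one pair covers only two small groups, so it sets no trend for this position. On these data alone, whether an amine, a carboxylic acid or a longer alkyl chain on the same carbon would leave the number within the scatter or move it beyond the scatter remains open.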